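Iodo to Methoxy on a Growth-Inhibiting Amide

This account rests on a few compounds, and the source may have more. Where it says the series, first, only, none or still open, it means among the compounds named here.

Compound 1 `NC(=O)c1cc(Cl)ccc1NC(=O)COc1ccccc1` gives 17000 nM
Compound 2 `NC(=O)c1cc(I)ccc1NC(=O)COc1ccccc1` gives 945 nM

In a functional assay on SN12C cells (Homo sapiens) for inhibition (on this read-out higher numbers stand for weaker inhibition of growth and lower numbers for stronger inhibition of growth), compound 2, at 945 nM, has the lower of the two measured numbers. Compound 3 `COc1ccc(NC(=O)COc2ccccc2)c(C(N)=O)c1` has not yet been measured. It carries methoxy in place of iodo on an aromatic carbon.

Going by the values given here, one measured step bears on this change, and it involves the same carbon: an 18-fold lower number from compound 1 to compound 2 (1.26 log units; beyond the scatter). That step is large and lies beyond the scatter, so the group on this carbon can clearly matter. Among the compounds with values here, no methoxy compound has been measured, however, and the size of the next step remains uncertain. With iodo leaving, a sizable move to a higher number is expected, beyond the scatter: a 7.4-fold higher number from compound 2 to compound 3 (0.87 log units; beyond the scatter). The estimated value for compound 3 is 7000 nM, with an expected range of 2000 nM to 25000 nM.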

Compound 3, concentration for 50% growth inhibition: 3090 nM
The estimate for compound 3 lay 2.3-fold (0.36 log units) above the measured number, and the stated range covers the measured number.
By their numbers in this assay, from the lowest: compound 2; then compound 3; then compound 1.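

In this assay the change from iodo to methoxy on this aromatic carbon gives a 3.3-fold higher number from compound 2 to compound 3 (0.51 log units; beyond the scatter) while the change from chloro to methoxy gives a 5.5-fold lower number from compound 1 to compound 3 (0.74 log units; beyond the scatter). Methoxy therefore falls between the two halogens, with both steps beyond the scatter, so a halogen is not needed on this carbon for a number well below that of the chloro compound, although iodo still gives the lowest number of the three. No measurement shown gives a reason for this order.

The compounds shown leave open where a bromo group, an amine or a carboxylic acid on this carbon would fall relative to these three. They also leave open whether the same order of iodo, methoxy and chloro would hold if the shared core were changed elsewhere.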